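This account rests on a few compounds, and the source may have more. Where it says the series, first, only, none or still open, it means among the compounds named here.

Measured compounds:
- compound 1 `O=C(/C=C\c1ccccc1)N1N=C(c2ccncc2)OC1c1c[nH]c2ccccc12`, in an ADME assay on HeLa cells (Homo sapiens) for cytotoxicity, read by MTT assay, with a stated time of 72 h (on this read-out higher numbers stand for weaker inhibition of growth and lower numbers for stronger inhibition of growth), compound 1 gives > 30 ug/mL, which is a limit of the assay.
- compound 2 `Cc1ccc(/C=C\C(=O)N2N=C(c3ccncc3)OC2c2c[nH]c3ccccc23)cc1`, in this assay compound 2 gives > 30 ug/mL, which is a limit of the assay.

Compound 2 therefore stands at the limit of > 30 ug/mL in this assay, at which 2 of the 2 values shown sit, and no number beyond that limit is known for it. Among the measured compounds shown here, the only measured step, a step that the two limits leave unreadable from compound 1 to compound 2, cannot be sized, since both ends are limits.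

Compound 3 `COc1ccc(/C=C\C(=O)N2N=C(c3ccncc3)OC2c2c[nH]c3ccccc23)cc1` differs from compound 2 by methoxy in place of methyl on an aromatic carbon. For the measured compounds named here, the measured step from compound 1 to compound 2 is the only comparison of the same kind available, and it gives no readable size, so there is nothing to set the scale of the new step. The expectation for compound 3 is therefore that its value stays near the limit where compound 2 sits. The step from compound 2 to compound 3 in this assay is estimated as a step that the limit leaves unreadable from compound 2 to compound 3. For compound 3 the estimate in this assay is 40 ug/mL, within a range from 15 ug/mL to 120 ug/mL.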

Compound 3, concentration for 50% growth inhibition: > 30 ug/mL
Compound 3 gave a limit, no number; the forecaster's own chance of this, stated with the estimate: 75%; the middle value does not contradict the limit.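

Compound 3 gives > 30 ug/mL in this assay, which is a limit and not a number. The steps linking compound 1, compound 2 and compound 3 therefore cannot be read: the limit of > 30 ug/mL in this assay, at which 3 of the 3 values shown sit. Going by these compounds, whether hydrogen, methyl or methoxy at this place changes growth inhibition at all stays open, since no true value is known for any of the three compounds.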